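Methylsulfonyl on the Nitrogen of Compound 1

The compounds below may be only part of what the source reports. "The series", "measured", "known", "first", "only" and "open" are said of these compounds alone.

In a functional assay on the whole organism with Mus musculus as the target (on this read-out lower numbers stand for an effect already at smaller amounts and higher numbers for an effect only at larger amounts of compound), compound 1 `Cc1c(C)c2c(c(C)c1N)CC(C)(C)O2` gives 7.8 mg/kg. Compound 3 `Cc1c(C)c2c(c(C)c1N)C(C(C)C)C(C)(C)O2` gives 14 mg/kg, which cannot be told apart from that number, and compound 2 `Cc1c(C)c2c(c(C)c1N)CC(C)(CSCCC(=O)O)O2` gives 43 mg/kg. Compound 4 `Cc1c(C)c2c(c(C)c1NS(C)(=O)=O)CC(C)(C)O2` keeps the core of compound 1 and differs in one place: methylsulfonyl in place of hydrogen on a nitrogen on an aromatic ring. Among the measured compounds shown here, this change, amino to methanesulfonamido, has no measured precedent, since neither known step touches that nitrogen. The known steps offer only loose guidance. One is a 1.8-fold higher number from compound 1 to compound 3 (0.25 log units; within the scatter), and the other is a 5.5-fold higher number from compound 1 to compound 2 (0.74 log units; beyond the scatter). Both added groups sit on saturated carbons instead, so only a moderate rise is expected, a 2.6-fold higher number from compound 1 to compound 4 (0.41 log units; beyond the scatter), with real uncertainty. Compound 4 is estimated at 20 mg/kg, within an expected range of 7 mg/kg to 60 mg/kg.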

Compound 4, dose for 50% inhibition: > 100 mg/kg
Compound 4: no number, only a limit (the forecaster's own chance of this, stated with the estimate: 15%); middle value at least 5.0-fold (0.69 log units) from the limit.
By their numbers in this assay, from the lowest: compounds 1 and 3 (each within the scatter of the next); then compound 2. At a limit, above all of these: compound 4.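

Until now, the only changes shown sat on saturated carbons. This result shows that the nitrogen on the aromatic ring is also sensitive to change: in this assay, methylsulfonyl in place of hydrogen there gives an at least 12-fold higher number from compound 1 to compound 4 (1.10 log units; beyond the scatter), which goes further than either change on a saturated carbon. The value of compound 4 is a limit and not a number, so the full size of this step remains unknown: the limit of > 100 mg/kg in this assay, at which 1 of the 4 values shown sits.

Methylsulfonyl is the only group measured on this nitrogen. An acetyl or a methyl there could show whether other groups in place of that hydrogen give a similar rise.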